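The compounds below may be only part of what the source reports. "The series", "measured", "known", "first", "only" and "open" are said of these compounds alone.

Compound 1 `CN1C[C@H](C(=O)Nc2ccccc2)[C@@H](c2ccc(/C=C/C(=O)Nc3ccccc3N)cc2)C1`: 67 mL/min/kg
Compound 2 `Cc1ccc(NC(=O)[C@H]2CN(C)C[C@@H]2c2ccc(/C=C/C(=O)Nc3ccccc3N)cc2)cc1`: 62 mL/min/kg
Compound 3 `COc1cccc(NC(=O)[C@H]2CN(C)C[C@@H]2c2ccc(/C=C/C(=O)Nc3ccccc3N)cc2)c1`: 65 mL/min/kg

In an in vitro ADME assay on microsomes from liver (Mus musculus) for pharmacokinetics, read by LC-MS, with a stated time of 10 min, tested at 1 uM (on this read-out higher numbers stand for fast clearance and lower numbers for slow clearance), compound 1 gives the highest of the three numbers shown, yet both other compounds sit within the scatter of it: a 1.1-fold lower number from compound 1 to compound 2 (0.03 log units; within the scatter) and a 1.0-fold lower number from compound 1 to compound 3 (0.01 log units; within the scatter). Compound 4 `CN1C[C@H](C(=O)Nc2ccc(F)c(Cl)c2)[C@@H](c2ccc(/C=C/C(=O)Nc3ccccc3N)cc2)C1` has not yet been measured. It differs from compound 1 by 3-chloro-4-fluorophenyl in place of phenyl on an amide-type nitrogen. The steps from compound 1 to compound 2 and from compound 1 to compound 3 bear on this change, as each also alters the group on an amide-type nitrogen, and both stayed within the scatter. Among the measured compounds shown here, no measured step introduces chlorine or fluorine, so the expectation rests on those two small steps alone: no movement beyond the scatter is expected, a 1.0-fold lower number from compound 1 to compound 4 (0.01 log units; within the scatter). Compound 4 is therefore estimated at 65 mL/min/kg, with a range from 40 mL/min/kg to 105 mL/min/kg.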

Compound 4, clearance: 34 mL/min/kg
Estimate against measurement, compound 4: 1.9-fold (0.28 log units) above; the measured number lies below the stated range.
By their numbers in this assay, from the lowest: compounds 4, 2, 3 and 1 (each within the scatter of the next).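

At this place on the amide-type nitrogen, in this assay, 3-chloro-4-fluorophenyl gives steps far larger than the earlier methyl and methoxy ones: a 2.0-fold lower number from compound 1 to compound 4 (0.29 log units; within the scatter) together with a 1.9-fold lower number from compound 3 to compound 4 (0.28 log units; within the scatter) and a 1.8-fold lower number from compound 2 to compound 4 (0.26 log units; within the scatter) all stay within the usual variation. The position therefore has not been shown to shift clearance, although these are the largest steps at it among the compounds shown. Nothing measured here accounts for the size of these steps. On these data alone, whether the chlorine or the fluorine alone would give a step of this size remains open. So does what an amine or a carboxylic acid on this phenyl would give.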